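The compounds below may be only part of what the source reports. "The series", "measured", "known", "first", "only" and "open" are said of these compounds alone.

Measured in an ADME assay on HEK293 cells (Homo sapiens) for cytotoxicity, with a stated time of 6 h; on this read-out higher numbers stand for lower toxicity in this test and lower numbers for higher toxicity in this test:
compound 1 `CCCCNc1nc(N)ncc1OCC`: > 25000 nM
compound 2 `CCCCNc1nc(N)nc2cc(CN(C)C)ccc12`: > 18000 nM
compound 3 `CCCCNc1nc(N)nc2cccc(OC)c12`: > 25000 nM

None of these three entries is a number; each is a limit of the assay. Compound 3 stands at > 25000 nM, which is a limit. Its place in the set is the limit of > 25000 nM in this assay, at which 2 of the 3 values shown sit. The remaining entry is the limit of > 18000 nM in this assay, at which 1 of the 3 values shown sits.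

Compound 4 `CCCCNc1nc(N)nc2cccc(OCc3ccccn3)c12` has not yet been measured. Its structural change from compound 3 is pyridin-2-yl in place of hydrogen on a saturated chain carbon bound to an oxygen on an aromatic ring, which turns methoxy into (pyridin-2-yl)methoxy. Among the measured compounds shown here, no pair of measured compounds here shows the size of any step, so the set offers no direct guide to this change. The only anchor for the expectation is compound 3 at > 25000 nM, again a limit. In this assay, no step beyond the scatter is expected, and any small movement is expected towards lower numbers, meaning higher toxicity in this test. The estimated change is an at least 1.1-fold lower number from compound 3 to compound 4 (0.05 log units; that floor lies within the scatter). For compound 4 the estimate is 22000 nM, with an expected range from 9000 nM to 50000 nM.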

Compound 4, half-maximal cytotoxic concentration: > 25000 nM
Compound 4: no number, only a limit; the forecaster's own chance of this, stated with the estimate: 70%; middle value at least 1.1-fold (0.05 log units) away from the limit.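

Among the compounds shown here, compound 3 and compound 4 both stand at a limit in this assay, and no step between them can be read. The compounds shown leave open where the true cytotoxic concentration of either compound lies, and whether (pyridin-2-yl)methoxy in place of methoxy shifts it at all.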